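The source may report more compounds than this note shows. Statements on the series, on what has been measured and on what is new or still open speak of the compounds shown alone.

Compound 2 `CN1C[C@H](C(=O)Nc2cccc(F)c2)[C@@H](c2ccc(/C=C/C(=O)Nc3ccccc3N)cc2)C1` is the compound from which this step sets out. Among the measured compounds shown here, in an in vitro ADME assay on microsomes from liver (Homo sapiens) for pharmacokinetics, read by LC-MS, with a stated time of 10 min, tested at 1 uM (a higher number here means faster removal of the compound, a lower number slower removal), compound 2 gives 6 mL/min/kg, the lowest of the three numbers measured so far; its nearest neighbour is compound 3 `CN1C[C@H](C(=O)Nc2cccc(Cl)c2)[C@@H](c2ccc(/C=C/C(=O)Nc3ccccc3N)cc2)C1`, which gives 7 mL/min/kg, and the furthest is compound 1 `Cc1ccc(NC(=O)[C@H]2CN(C)C[C@@H]2c2ccc(/C=C/C(=O)Nc3ccccc3N)cc2)cc1`, which gives 15 mL/min/kg. The steps that were measured all concern the group on the amide-type nitrogen: a 2.5-fold lower number from compound 1 to compound 2 (0.40 log units; beyond the scatter) and a 2.1-fold lower number from compound 1 to compound 3 (0.33 log units; beyond the scatter), while a 1.2-fold higher number from compound 2 to compound 3 (0.07 log units; within the scatter). The new compound 4 `CN1C[C@H](C(=O)NC2CCCC2)[C@@H](c2ccc(/C=C/C(=O)Nc3ccccc3N)cc2)C1` carries a change at the same place, (cyclopentyl in place of 3-fluorophenyl on an amide-type nitrogen). For the measured compounds named here, none of the measured steps replaces the aromatic ring at this position by a non-aromatic one, so no measured step covers this change directly; the measured steps only show that changes at this position have moved the number by modest amounts. The number for compound 4 is therefore expected to shift by a 1.7-fold higher number from compound 2 to compound 4 (0.22 log units; within the scatter), a step that may stay within the scatter. For compound 4 the estimate in this assay is 10 mL/min/kg, with a range from 5 mL/min/kg to 22 mL/min/kg.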

Compound 4, clearance: 9 mL/min/kg
Compound 4: middle estimate off by 1.1-fold (0.05 log units), on the high side; the range from low to high includes it.
By their numbers in this assay, from the lowest: compounds 2, 3, 4 and 1 (each within the scatter of the next, the first and the last beyond it).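

With cyclopentyl on the amide-type nitrogen, compound 4 shows that a non-aromatic ring can take the place of the aromatic ones at this position and leave the number in this assay within the scatter of both halogenated phenyl compounds (a 1.5-fold higher number from compound 2 to compound 4 (0.18 log units; within the scatter); a 1.3-fold higher number from compound 3 to compound 4 (0.11 log units; within the scatter)). The 4-methylphenyl compound also stays within the scatter of it (a 1.7-fold lower number from compound 1 to compound 4 (0.22 log units; within the scatter)), so compound 4, unlike compound 2 and compound 3, is not separated beyond the scatter from compound 1. The data shown offer no measured evidence that would explain these numbers.

With only one non-aromatic group at this position, the compounds shown leave open whether this holds for other such groups, for instance cyclohexyl or an open butyl chain. They also leave open how this assay would read with a saturated ring that carries an amine or a carboxylic acid on this nitrogen.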